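Halogen swap on a benzotriazolyl-methyl oxadiazole series

The source may report more compounds than this note shows. Statements on the series, on what has been measured and on what is new or still open speak of the compounds shown alone.

Of the compounds shown here, three have been measured in a functional assay on MCF7 cells (Homo sapiens) for antiproliferative activity, read by MTT assay, with a stated time of 24 h; a higher number here means a weaker inhibitor, a lower number a stronger inhibitor. Compound 1 `Clc1cccc(Cc2nnc(Cn3nnc4ccccc43)o2)c1` gives 292000 nM. Compound 2 `Fc1cccc(Cc2nnc(Cn3nnc4ccccc43)o2)c1` gives 357000 nM in this assay. Compound 3 `Clc1cccc(-c2nnc(Cn3nnc4ccccc43)o2)c1` gives 390000 nM in this assay. The step from compound 1 to compound 2 is a 1.2-fold higher number from compound 1 to compound 2 (0.09 log units; within the scatter), so these two values do not separate. Compound 3 sits with them inside the same scatter, and the difference between the core of compound 3 and the core of compound 1 is not broken down here.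

Compound 4 `Fc1cccc(-c2nnc(Cn3nnc4ccccc43)o2)c1` is not yet measured. It differs from compound 3 as fluoro in place of chloro on an aromatic carbon. Compound 2 differs from compound 1 in the same way, (fluoro in place of chloro on an aromatic carbon), and the two place lines agree word for word, so the change is the same one made on the other core. In this assay the step from compound 3 to compound 4 is expected to be about a 1.2-fold higher number from compound 3 to compound 4 (0.08 log units; within the scatter), beside the earlier step; this rests on the step from compound 1 to compound 2 of a 1.2-fold higher number from compound 1 to compound 2 (0.09 log units; within the scatter), which stayed within scatter. Compound 4 is therefore estimated at 470000 nM in this assay, with a range from 250000 nM to 900000 nM.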

Compound 4, half-maximal inhibitory concentration: 398000 nM
For compound 4 the middle estimate is 1.2-fold (0.07 log units) above the measured one, within the range that was stated.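

In this assay the change from 3-chlorophenyl to 3-fluorophenyl gives a 1.0-fold higher number from compound 3 to compound 4 (0.01 log units; within the scatter), so compound 3 and compound 4 do not separate. Set beside the same change on the other core, the two steps agree: the same change on two cores in this assay, a 1.2-fold higher number (0.09 log units; within the scatter) from compound 1 to compound 2 and a 1.0-fold higher number (0.01 log units; within the scatter) from compound 3 to compound 4, 1.2-fold (0.08 log units) apart, within the scatter of two such steps

On both cores, then, the swap of chloro for fluoro leaves the number inside the scatter, and in this series the null result carries from one core to the other. This does not show that a step of real size would carry across in the same way, as neither step here is large enough to test that.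

The compounds shown leave open whether any group on the six-membered aromatic ring moves the number at all, as only chloro and fluoro appear there, and a methoxy group, an amine or a carboxylic acid in that place would test this. Also open, on these data alone, is whether the swap would stay this small on a core bearing a longer chain.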